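The compounds below may be only part of what the source reports. "The series", "measured", "known", "first", "only" and "open" are said of these compounds alone.

Compound 1 `Cc1cccc(/C=N/c2ccc(OCc3ccccc3)cc2)c1O`: in a functional assay, with a stated time of 30 min (a lower number here means a stronger inhibitor, a higher number a weaker inhibitor), compound 1 gives > 200000 nM, a limit of the assay rather than a number. Compound 2 `COc1cccc(/C=N/c2ccc(OCc3ccccc3)cc2)c1O`: in this assay compound 2 gives > 200000 nM, likewise a limit. Compound 3 `Cc1ccc(/C=N/c2ccc(OCc3ccccc3)cc2)c(O)c1`: in this assay compound 3 gives > 200000 nM, again a limit.

The change from compound 1 to compound 2, (methoxy in place of methyl on an aromatic carbon), made a step that the two limits leave unreadable from compound 1 to compound 2, unreadable because of the limit of > 200000 nM in this assay, at which 3 of the 3 values shown sit. The cores of compound 1 and compound 3 differ by 2-hydroxy-4-methylphenyl in place of 2-hydroxy-3-methylphenyl on a carbon with a double bond to nitrogen, a step that the two limits leave unreadable from compound 1 to compound 3. Compound 4 `COc1ccc(/C=N/c2ccc(OCc3ccccc3)cc2)c(O)c1` carries the same kind of change, (methoxy in place of methyl on an aromatic carbon), though here it sits meta to a hydroxy group and para to a large group rather than ortho to a hydroxy group and meta to a large group. Because the earlier change gave a step that the two limits leave unreadable from compound 1 to compound 2, compound 4 is expected to move by a number no higher from compound 3 to compound 4 (the limit leaves the size open) in this assay. Compound 4 is accordingly estimated at 200000 nM.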

Compound 4, half-maximal inhibitory concentration: > 200000 nM
Compound 4: no number, only a limit; the forecaster's own chance of this, stated with the estimate: 85%; the middle value lies on the limit itself.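

Compound 4 also stands at a limit, so no size can be read for the step from compound 3 to compound 4: the limit of > 200000 nM in this assay, at which 4 of the 4 values shown sit. From the compounds shown here alone, how strongly any of the four compounds inhibits in this assay stays open.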